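The source may hold more compounds than are shown below. What is called first, only, known or untested is meant among the compounds shown, and "the series" means these compounds.

Measured compounds:
- compound 1, `CCCCCCCCNC(=O)[C@H]1OC(n2cnc3c(N)ncnc32)[C@H](O)[C@@H]1O`: in an assay on cell membranes for binding affinity to 2-oxoglutarate receptor 1 (Rattus norvegicus), read by radioligand binding (on this read-out higher numbers stand for weaker inhibition and lower numbers for stronger inhibition), compound 1 gives 21 nM
- compound 2, `CC(=O)NCCNC(=O)[C@H]1OC(n2cnc3c(N)ncnc32)[C@H](O)[C@@H]1O`: in this assay compound 2 gives 46 nM

Within the data shown here, of the two numbers so far, compound 2 stands highest, its nearest neighbour being compound 1, which differs by a 2.2-fold higher number from compound 1 to compound 2 (0.34 log units; beyond the scatter). That single step replaced hexyl by acetamido on a saturated chain carbon two bonds along the chain from the amide-type nitrogen, and it shifted the number by a modest amount.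

Compound 3, `Nc1ncnc2c1ncn2C1O[C@H](C(=O)NO)[C@@H](O)[C@H]1O`, is built from compound 2 by a different kind of change: hydroxy in place of 2-acetamidoethyl on an amide-type nitrogen. Here the whole 2-acetamidoethyl chain on the amide-type nitrogen is removed and a hydroxy takes its place, so the amide-type nitrogen now carries only hydroxy and the carbonyl carbon. The step from compound 1 to compound 2 is the only one recorded and it touches the chain rather than the nitrogen itself, so it bears on this change only indirectly; it shows that shortening the chain moved the number upward. Since compound 3 removes the chain altogether, compound 3 is expected to give a higher number in this assay, a step of a 3.3-fold higher number from compound 2 to compound 3 (0.51 log units; beyond the scatter), with the direction taken from the step from compound 1 to compound 2 and the size uncertain. The estimate for compound 3 in this assay is 150 nM, expected between 40 nM and 600 nM.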

Compound 3, inhibition constant: 41 nM
Compound 3: middle estimate off by 3.7-fold (0.56 log units), on the high side, within the range that was stated.
By their numbers in this assay, from the lowest: compounds 1, 3 and 2 (each within the scatter of the next, the first and the last beyond it).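

In this assay, hydroxy in place of 2-acetamidoethyl on the amide-type nitrogen gives a 1.1-fold lower number from compound 2 to compound 3 (0.05 log units; within the scatter) and hydroxy in place of octyl on that nitrogen gives a 2.0-fold higher number from compound 1 to compound 3 (0.29 log units; within the scatter), so neither replacement moves the number beyond the scatter. The earlier step concerned only the far part of the chain, whereas these steps show that a whole chain on this nitrogen can give way to hydroxy, a single heavy atom, with the number staying within the scatter of both chain-bearing compounds, even though those two compounds lie beyond the scatter of each other. No measurement shown gives a reason for this result.

The compounds shown leave open whether the hydroxy itself matters at this nitrogen, since they include no compound with a methoxy, a methyl or only a hydrogen in its place. They also leave open how a chain ending in an amine or a carboxylic acid, or one longer than octyl, would compare on this nitrogen.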